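Cyclohexylmethyl in place of fluorophenyl on the hydrazide chain

A few compounds are considered here, and "the series" means these few. Any claim that something is new, unique, unknown or untested is made for them only; others in the source may bear on it.

Compound 1 `O=C(CCc1ccc(F)cc1)NNc1c(Cl)cncc1Cl` and compound 2 `O=C(CCc1cccc2ccccc12)NNc1c(Cl)cncc1Cl` share one core and were tested in a functional assay on HEK293 cells for antagonist activity at P2X purinoceptor 7 (Homo sapiens), read by fluorescence, with a stated time of 2 h; a lower number here means a stronger inhibitor, a higher number a weaker inhibitor. Compound 1 gives 900 nM, and compound 2 gives 1200 nM; the two numbers lie within the usual scatter of each other, so neither stands apart. Compound 3 `O=C(CCCC1CCCCC1)NNc1c(Cl)cncc1Cl` is not yet measured. It differs from compound 1 by cyclohexylmethyl in place of 4-fluorophenyl on a saturated chain carbon, two bonds along the chain from a carbonyl carbon. Going by the values given here, no measured pair shows this change, so only a modest step is expected, a 1.7-fold higher number from compound 1 to compound 3 (0.22 log units; within the scatter), toward a somewhat weaker inhibitor. Compound 3 is therefore estimated at 1500 nM, within 600 nM to 4000 nM.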

Compound 3, half-maximal inhibitory concentration: 360 nM
Beside the measured number, compound 3's estimate is 4.2-fold (0.62 log units) above it; measured number outside the range, below it.
By their numbers in this assay, from the lowest: compound 3; then compounds 1 and 2 (each within the scatter of the next).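

In this assay cyclohexylmethyl in place of 4-fluorophenyl gives a 2.5-fold lower number from compound 1 to compound 3 (0.40 log units; beyond the scatter) and so a stronger inhibitor. At this place on the chain, then, a six-membered aromatic ring of carbon only is not required, and a six-membered non-aromatic ring of carbon only gives the lower number. Nothing shown here accounts for the step.

The compounds shown leave open whether the ring matters at all, or whether an open-chain group such as n-hexyl would serve as well. They also leave open how a hydroxyl or an amine on the cyclohexane ring would fare.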